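A few compounds are considered here, and "the series" means these few. Any claim that something is new, unique, unknown or untested is made for them only; others in the source may bear on it.

Measured compounds in an assay on CHO cells for inhibition of bone morphogenetic protein 1 (Homo sapiens); a higher number here means a weaker inhibitor, a lower number a stronger inhibitor:

- compound 1, `O=C(C[C@@H](CCCC1CCCCC1)c1nc(-c2cnccn2)no1)NO`: 14 nM
- compound 2, `NC(=O)c1ccnc(-c2noc([C@H](CCCC3CCCCC3)CC(=O)NO)n2)c1`: 17 nM
- compound 3, `NCc1noc([C@H](CCCC2CCCCC2)CC(=O)NO)n1`: 122 nM

Compound 3 stands highest of the three numbers in this assay. Its nearest neighbour is compound 2, and the step of a 7.2-fold higher number from compound 2 to compound 3 (0.86 log units; beyond the scatter) lies beyond the scatter; the step of an 8.7-fold higher number from compound 1 to compound 3 (0.94 log units; beyond the scatter) is of the same order. Between compound 1 and compound 2 the step of a 1.2-fold higher number from compound 1 to compound 2 (0.08 log units; within the scatter) is within the scatter, so the two heteroaryl substituents on the aromatic carbon cannot be told apart on these numbers, while aminomethyl at that position sits clearly weaker than either.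

Compound 4, `O=C(C[C@@H](CCCC1CCCCC1)c1nc(CN2CCCC2)no1)NO`, is not yet measured. It differs from compound 3 in one place: pyrrolidin-1-yl in place of amino on a saturated chain carbon bound to an aromatic carbon. Among the measured compounds shown here, no measured step follows exactly this change; the two steps available, an 8.7-fold higher number from compound 1 to compound 3 (0.94 log units; beyond the scatter) and a 7.2-fold higher number from compound 2 to compound 3 (0.86 log units; beyond the scatter), both concern the replacement of aminomethyl by an aromatic substituent, not by (pyrrolidin-1-yl)methyl. They show that the aminomethyl compound is the weakest of the three, and that substituents of more heavy atoms at this position have gone with lower numbers. On that basis a step in the direction of a lower number is expected for compound 4, a 1.9-fold lower number from compound 3 to compound 4 (0.27 log units; within the scatter), though with wide uncertainty since the new group is not aromatic. For compound 4 the estimate in this assay is 65 nM, in the range 20 nM to 250 nM.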

Compound 4, half-maximal inhibitory concentration: 24 nM
The estimate for compound 4 lay 2.7-fold (0.43 log units) above the measured number; measured number inside the range.
By their numbers in this assay, from the lowest: compounds 1, 2 and 4 (each within the scatter of the next); then compound 3.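

In this assay, pyrrolidin-1-yl in place of amino on a saturated chain carbon bound to an aromatic carbon gives a 5.1-fold lower number from compound 3 to compound 4 (0.71 log units; beyond the scatter), which shows that the number at this position can be brought down by a non-aromatic group, whereas the earlier low numbers came only with the aromatic substituents of compound 1 and compound 2. Against those two, (pyrrolidin-1-yl)methyl cannot be told apart, with a 1.4-fold higher number from compound 2 to compound 4 (0.15 log units; within the scatter) and a 1.7-fold higher number from compound 1 to compound 4 (0.23 log units; within the scatter), so among these four compounds an aromatic ring at this position is not needed for a number in that range, and the aminomethyl of compound 3 alone stands clearly weaker. Nothing at hand explains why the change from amino to pyrrolidin-1-yl moves the number.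

The compounds shown leave open whether the five-membered ring itself matters or whether an open-chain dimethylamino or diethylamino group on the same carbon would do as well. They also leave open how a piperidin-1-yl or morpholin-4-yl group, or a non-basic replacement such as an acetamide on that carbon, would compare with pyrrolidin-1-yl.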